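Swapping an amino ester for tert-butyl on the alkyne chain

A few compounds are considered here, and "the series" means these few. Any claim that something is new, unique, unknown or untested is made for them only; others in the source may bear on it.

- compound 1 `CN1CCN(CC#Cc2cc3ncnc(Nc4ccc(OCc5cccc(F)c5)c(Cl)c4)c3s2)CC1` gives 11 uM
- compound 2 `CCOC(=O)CN(C)CC#Cc1cc2ncnc(Nc3ccc(OCc4cccc(F)c4)c(Cl)c3)c2s1` gives 26 uM

In an ADME assay on HepG2 cells (Homo sapiens) for cytotoxicity (a higher number here means that more compound is tolerated, a lower number that less compound is tolerated), compound 2 gives 26 uM and stands highest of the two numbers. Compound 3 `CC(C)(C)CC#Cc1cc2ncnc(Nc3ccc(OCc4cccc(F)c4)c(Cl)c3)c2s1` changes one group on a saturated chain carbon bound to a triple-bonded carbon (tert-butyl in place of ((ethoxycarbonyl)methyl)(methyl)amino on a saturated chain carbon bound to a triple-bonded carbon). Among the measured compounds shown here, the only measured swap at that place is modest (a 2.4-fold higher number from compound 1 to compound 2 (0.37 log units; beyond the scatter)) and shows no direction for tert-butyl, so a step of similar or smaller size is expected, leaning towards compound 1 (11 uM). The step expected is small (a 1.4-fold lower number from compound 2 to compound 3 (0.16 log units; within the scatter)). For compound 3 the estimated value is 18 uM (expected range 7 uM to 45 uM).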

Compound 3, half-maximal toxic concentration: 29.3 uM
Beside the measured number, compound 3's estimate is 1.6-fold (0.21 log units) below it; measured number inside the range.
By their numbers in this assay, from the lowest: compound 1; then compounds 2 and 3 (each within the scatter of the next).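

At this place, on a saturated chain carbon bound to a triple-bonded carbon, tert-butyl and ((ethoxycarbonyl)methyl)(methyl)amino cannot be told apart in this assay (a 1.1-fold higher number from compound 2 to compound 3 (0.05 log units; within the scatter)). An all-carbon group thus reads like the amino ester, and 4-methylpiperazin-1-yl alone stands apart from both (a 2.7-fold higher number from compound 1 to compound 3 (0.43 log units; beyond the scatter)). No measurement here offers an explanation for this.

A dimethylamino group at this place could show whether the lower number goes with 4-methylpiperazin-1-yl alone. Going by these compounds, a carboxylic acid in place of the ethyl ester also remains open.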